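A New Group on an Aromatic Nitrogen of Compound 2

The source may hold more compounds than are shown below. What is called first, only, known or untested is meant among the compounds shown, and "the series" means these compounds.

In a functional assay on BT-474 cells (Homo sapiens) for inhibition, read by MTT assay, with a stated time of 5 days (on this read-out higher numbers stand for weaker inhibition and lower numbers for stronger inhibition), compound 1 (`Cc1cc(Nc2nc(NCc3ccc(Cl)cc3)nc3[nH]ncc23)n[nH]1`) gives 11700 nM and compound 2 (`Cc1cc(Nc2nc(NCc3ccc(F)cc3F)nc3[nH]ncc23)n[nH]1`) gives 3220 nM as the lower of the two numbers, so compound 2 is the stronger inhibitor so far. The next structure, compound 3 (`Cc1cc(Nc2nc(NCc3ccc(F)cc3F)nc3c2cnn3CC(C)(C)O)n[nH]1`), differs from compound 2 by 2-hydroxy-2-methylpropyl in place of hydrogen on an aromatic nitrogen and so carries 2-hydroxy-2-methylpropyl in place of hydrogen on an aromatic nitrogen. Among the measured compounds shown here, the one measured step is a 3.6-fold lower number from compound 1 to compound 2 (0.56 log units; beyond the scatter) and was modest, but it swapped 4-chlorophenyl for 2,4-difluorophenyl elsewhere in the molecule, so it offers only a loose guide to size. For the measured compounds named here, no measured step touches the aromatic nitrogen, which leaves the outcome in this assay uncertain. The expected change is a 1.8-fold lower number from compound 2 to compound 3 (0.25 log units; within the scatter) and would be a modest move toward stronger inhibition. For compound 3 the estimated value is 1800 nM with an expected range from 400 nM to 8000 nM as a working guess.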

Compound 3, half-maximal inhibitory concentration: 19400 nM
Estimate against measurement, compound 3: 11-fold (1.03 log units) below; the measured number lies above the stated range.
By their numbers in this assay, from the lowest: compound 2; then compounds 1 and 3 (each within the scatter of the next).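

In this assay, putting 2-hydroxy-2-methylpropyl in place of hydrogen on the aromatic nitrogen gives a 6.0-fold higher number from compound 2 to compound 3 (0.78 log units; beyond the scatter) and so moves toward weaker inhibition. Among the compounds shown here, this is the first measured change at this nitrogen, and it shows that the position is not indifferent to what sits on it; the earlier step changed only the aromatic ring on the chain carbon and said nothing about this site. No measurement shown here explains why the number rose.

With a single group shown on this nitrogen, it stays open whether the loss belongs to 2-hydroxy-2-methylpropyl itself or would follow from any group placed there. A methyl, or a longer chain ending in an amine or a carboxylic acid, would help separate these two readings.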